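A few compounds are considered here, and "the series" means these few. Any claim that something is new, unique, unknown or untested is made for them only; others in the source may bear on it.

Working notes on the series. Compound 1 `COc1cc(-c2nc(SCc3cn(CC(=O)NC(=O)Nc4ccccn4)nn3)nc(Nc3cccc(C(F)(F)F)c3)c2C#N)cc(OC)c1OC` and compound 2 `Cc1ccc(-c2nc(SCc3cn(CC(=O)NC(=O)Nc4ccccn4)nn3)nc(Nc3ccc(C(C)C)cc3)c2C#N)cc1` share one core. In an ADME assay on GES1 cells (Homo sapiens) for inhibition, read by MTT assay, with a stated time of 72 h (a lower number here means a stronger inhibitor, a higher number a weaker inhibitor), compound 1 gives only a limit, > 64000 nM. Compound 2 likewise gives only a limit in this assay, > 64000 nM. The evidence so far reads (the limit of > 64000 nM in this assay, at which 2 of the 2 values shown sit). Compound 3 `COc1ccc(Nc2nc(SCc3cn(CC(=O)NC(=O)Nc4ccccn4)nn3)nc(-c3ccc(C)cc3)c2C#N)cc1` is not yet measured and differs from compound 2 by methoxy in place of isopropyl on an aromatic carbon. No step between measured compounds is available, and with both shown values at a limit no direction can be read. The step from compound 2 to compound 3 in this assay is expected to be a step that the limit leaves unreadable from compound 2 to compound 3, none beyond the scatter. Compound 3 is expected to give 80000 nM, in the range 30000 nM to 200000 nM, most likely again reported only as a limit.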

Compound 3, half-maximal inhibitory concentration: 35700 nM
Estimate against measurement, compound 3: 2.2-fold (0.35 log units) above; measured number inside the range.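

Among the compounds shown here, with methoxy in place of isopropyl on this aromatic carbon, compound 3 gives 35700 nM in this assay, the first number that is not a limit. From the compounds shown here alone, the change reads as an at least 1.7-fold lower number from compound 2 to compound 3 (0.25 log units; that floor lies within the scatter); this is only a floor, and the full size of the step stays unknown. The other values remain limits: the limit of > 64000 nM in this assay, at which 2 of the 3 values shown sit.

Still open, going by these compounds, is how an amine or a carboxylic acid on this aromatic carbon would read in this assay. Also open, on these data alone, is whether a longer chain, such as propoxy, would give a number or return to the limit.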